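Dimethylamino in place of amino at the assay limit

The source may report more compounds than this note shows. Statements on the series, on what has been measured and on what is new or still open speak of the compounds shown alone.

Compound 1 `CCN(CC)Cc1ccc2c(c1O)-c1ccc(cc1O)CCc1ccc(O)c(c1)Oc1ccc(cc1)CC2`: 7590 nM
Compound 2 `O=[N+]([O-])c1cc2cc(c1O)Oc1ccc(cc1)CCc1cccc(O)c1-c1ccc(cc1O)CC2`: > 20000 nM (a limit)
Compound 3 `Nc1cc2cc(c1O)Oc1ccc(cc1)CCc1cccc(O)c1-c1ccc(cc1O)CC2`: > 20000 nM (a limit)

All three results come from a functional assay on MCF7 cells (Homo sapiens) for antiproliferative activity, read by MTT assay, with a stated time of 48 h; on this read-out higher numbers stand for weaker inhibition and lower numbers for stronger inhibition. Compound 3 reads > 20000 nM, which is a limit of the assay and not a number. Compound 2 reads > 20000 nM, also a limit. That is the limit of > 20000 nM in this assay, at which 2 of the 3 values shown sit. So the starting point for the next step is known only as a limit.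

The next compound is compound 4 `CN(C)c1cc2cc(c1O)Oc1ccc(cc1)CCc1cccc(O)c1-c1ccc(cc1O)CC2`. It carries dimethylamino in place of amino on an aromatic carbon, ortho to a hydroxy group (dimethylamino in place of amino on an aromatic carbon).

Among the measured compounds shown here, the only measured step at this carbon is a step that the two limits leave unreadable from compound 2 to compound 3, so it offers no size to carry over. Compound 1, which has a diethylaminomethyl group, gives a real number of 7590 nM. However, it differs from compound 3 in more than one place, so it is only a loose guide. On this evidence no clear gain in this assay is expected, and the result will most likely stay close to the limit. The estimated step is a step that the limit leaves unreadable from compound 3 to compound 4, and it carries wide uncertainty. For compound 4 the expected value is 22000 nM, with an estimated range of 9000 nM to 50000 nM.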

Compound 4, half-maximal inhibitory concentration: > 20000 nM
Compound 4 was reported as a limit; the forecaster's own chance of this, stated with the estimate: 70%; the middle value lies beyond the limit too.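

In this assay compound 4 reads > 20000 nM, which is a limit of the assay and not a number. No step among compound 2, compound 3 and compound 4 can be read, because all three sit at the same limit: the limit of > 20000 nM in this assay, at which 3 of the 4 values shown sit.

From the compounds shown here alone, whether nitro, amino and dimethylamino on this aromatic carbon differ in strength of inhibition stays open.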